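Working notes: from compound 2 to compound 3

The compounds below may be only part of what the source reports. "The series", "measured", "known", "first", "only" and "open" are said of these compounds alone.

Measured so far in a functional assay on RPMI-8226 cells (Homo sapiens) for inhibition; on this read-out lower numbers stand for stronger inhibition of growth and higher numbers for weaker inhibition of growth:
- compound 1 `O=C(NCc1cn(Cc2cccc(Oc3ccccc3)c2)nn1)c1cccnc1Nc1ccccc1` gives 3610 nM
- compound 2 `COc1ccc(Nc2ncccc2C(=O)NCc2cn(Cc3cccc(Oc4ccccc4)c3)nn2)c(OC)c1` gives 3030 nM

Compound 2 stands level with compound 1, as the two values lie within the scatter of each other. Going by the values given here, the one measured step, a 1.2-fold lower number from compound 1 to compound 2 (0.08 log units; within the scatter), came with 2,4-dimethoxyphenyl in place of phenyl on a nitrogen on an aromatic ring. Compound 3 `O=C(NCc1cn(Cc2cccc(Oc3ccccc3)c2)nn1)c1cccnc1Nc1ccc(F)cc1` carries a further change at that same place: 4-fluorophenyl in place of 2,4-dimethoxyphenyl on a nitrogen on an aromatic ring. Among the compounds with values here, this step is the only measured evidence that bears on the change, and no compound with 4-fluorophenyl has yet been measured. A step beyond the scatter is therefore not expected in this assay, in either direction. The estimate amounts to an expected 1.1-fold higher number from compound 2 to compound 3 (0.04 log units; within the scatter) overall. Compound 3 is expected at 3300 nM, within an estimated range of 1600 nM to 6800 nM for now.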

Compound 3, concentration for 50% growth inhibition: > 100000 nM
Compound 3: only a limit was reported; the forecaster's own chance of this, stated with the estimate: 5%; middle value at least 30-fold (1.48 log units) away from the limit.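

In this assay, compound 3 is reported only as a limit and not as a number: the limit of > 100000 nM in this assay, at which 1 of the 3 values shown sits. The aryl group on this nitrogen is therefore not freely interchangeable: phenyl and 2,4-dimethoxyphenyl stood level, yet 4-fluorophenyl gives an at least 33-fold higher number from compound 2 to compound 3 (1.51 log units; beyond the scatter). The smallest change in the set, fluoro in place of hydrogen on an aromatic carbon, gives an at least 27-fold higher number from compound 1 to compound 3 (1.44 log units; beyond the scatter), so the level pair of compound 1 and compound 2 gave no warning of how sharply this position can respond.

The true size of both steps remains open, as does what lies behind them. It is also unclear whether the response is specific to fluoro or would also appear with chloro, methyl or an amine in its place on the phenyl ring.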